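The source may hold more compounds than are shown below. What is called first, only, known or untested is meant among the compounds shown, and "the series" means these compounds.

Measured compounds:
- compound 1 `CNc1nc(NCc2ccc(Cl)cc2Cl)cc(-c2ccccn2)n1`: 0.5 nM
- compound 2 `CC(C)(C)CNc1nc(NCC2CC2)cc(-c2ccccn2)n1`: 1500 nM

In a functional assay on HEK293 cells for agonist activity at G-protein coupled receptor 39 (Mus musculus), read by inositol phosphate accumulation (a higher number here means that more compound is needed for the effect, a lower number that less compound is needed), compound 1 gives 0.5 nM, the lowest of the two numbers; compound 2 gives 1500 nM, a gap well beyond the scatter. Compound 3 `CNc1nc(NCC2CCCCC2)cc(-c2ccccn2)n1` has not yet been measured. It keeps the core of compound 1 and carries cyclohexyl in place of 2,4-dichlorophenyl on a saturated chain carbon bound to a nitrogen on an aromatic ring. Within the data shown here, no measured pair isolates this single change, so its size is uncertain. Trading the aromatic ring for a saturated one is expected to cost activity, with a 60-fold higher number from compound 1 to compound 3 (1.78 log units; beyond the scatter) beyond the scatter. Compound 3 is therefore estimated at 30 nM, within 4 nM to 300 nM.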

Compound 3, half-maximal effective concentration: 10 nM
For compound 3 the middle estimate is 3.0-fold (0.48 log units) above the measured one; the range from low to high includes it.
By their numbers in this assay, from the lowest: compound 1; then compound 3; then compound 2.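

In this assay, among these compounds, cyclohexyl in place of 2,4-dichlorophenyl on a saturated chain carbon bound to a nitrogen on an aromatic ring gives a 20-fold higher number from compound 1 to compound 3 (1.30 log units; beyond the scatter), the first comparison that isolates this position. An aromatic ring with two chlorines is thus not required for activity: compound 3, with a saturated ring and no chlorine, still gives 10 nM. Nothing available explains the size of this step.

Still open, as far as these compounds go, is how much of the step comes from losing the chlorines and how much from losing the aromatic ring. A plain phenyl group at the same place would separate the two.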